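The source may hold more compounds than are shown below. What is called first, only, known or untested is meant among the compounds shown, and "the series" means these compounds.

Of the compounds shown here, three have been tested in an ADME assay on cells (Homo sapiens) for cytotoxicity, read by resazurin assay, with a stated time of 5 days; a lower number here means that less compound is tolerated, a higher number that more compound is tolerated. Compound 1, `COc1ccc(-c2nc(C(C)(C)S(=O)(=O)c3cccc(Cl)c3)nc3ccsc23)cn1`, gives > 50000 nM, which is a limit of the assay rather than a number. Compound 2, `CCC1=C(C(=O)OCC2CCCCC2)C(c2cccc(O)c2)NC(=O)N1`, gives > 10000 nM, again a limit of the assay. Compound 3, `O=S(=O)(Cc1nc(-c2ccc(Cl)nc2)c2sccc2n1)c1cccc(Cl)c1`, is the only one of the three with a measured number, 70000 nM, so it stands as the sole fixed point here. Compound 4, `O=S(=O)(Cc1nc(-c2ccc(F)nc2)c2sccc2n1)c1cccc(Cl)c1`, has not yet been measured. It differs from compound 3 by fluoro in place of chloro on an aromatic carbon. Within the data shown here, no pair of measured compounds shows what such a change does in this assay. Compound 4 is therefore expected to sit close to compound 3, with a step of no change at the digits printed from compound 3 to compound 4 (within the scatter) that stays within the scatter. The estimated value for compound 4 is 70000 nM, in a range from 30000 nM to 150000 nM.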

Compound 4, half-maximal cytotoxic concentration: 40000 nM
Estimate against measurement, compound 4: 1.8-fold (0.24 log units) above, within the range that was stated.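

Going from 6-chloropyridin-3-yl to 6-fluoropyridin-3-yl gives the first direct reading of a single change in this assay and the result is a 1.8-fold lower number from compound 3 to compound 4 (0.24 log units; within the scatter) as the step. At this aromatic carbon, next to the ring nitrogen, chloro and fluoro therefore cannot be told apart in this read-out. Nothing measured here offers a cause for this result. Still open, going by these compounds, is whether an amine or a carboxylic acid on this same carbon would move the number beyond the scatter.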